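The source may hold more compounds than are shown below. What is called first, only, known or untested is meant among the compounds shown, and "the series" means these compounds.

Measured in a functional assay on HCT-116 cells (Homo sapiens) for inhibition, read by MTT assay, with a stated time of 48 h; a lower number here means a stronger inhibitor, a higher number a weaker inhibitor:
Compound 1 `COc1ccc(CSc2nnc(-c3cc(OC)c(OC)c(OC)c3)n2-c2ccc(OC)cc2)cc1`: 49600 nM.
Compound 2 `COc1ccc(-n2c(SCC(=O)c3ccc4ccccc4c3)nnc2-c2cc(OC)c(OC)c(OC)c2)cc1`: > 60000 nM, a limit of the assay.
Compound 3 `COc1ccc(CSc2nnc(-c3cc(OC)c(OC)c(OC)c3)n2-c2ccc(N(C)C)cc2)cc1`: 1150 nM.

Compound 3 holds the lowest number among these, reached by a 43-fold lower number from compound 1 to compound 3 (1.63 log units; beyond the scatter). Compound 4 `COc1ccc(C(=O)CSc2nnc(-c3cc(OC)c(OC)c(OC)c3)n2-c2ccc(N(C)C)cc2)cc1O` keeps the dimethylamino group of compound 3 and differs from it in one place: (3-hydroxy-4-methoxyphenyl)carbonyl in place of 4-methoxyphenyl on a saturated chain carbon bound to a sulfur. In words, (3-hydroxy-4-methoxyphenyl)carbonyl stands in place of 4-methoxyphenyl on a saturated chain carbon bound to a sulfur. Among the measured compounds shown here, the only measured change at that place is an at least 1.2-fold higher number from compound 1 to compound 2 (0.08 log units; that floor lies within the scatter), whose true size stays open at the limit of > 60000 nM in this assay, at which 1 of the 3 values shown sits. It brought in a different carbonyl group and gives no firm direction. The step expected in this assay is therefore a 1.3-fold higher number from compound 3 to compound 4 (0.12 log units; within the scatter), nothing beyond the scatter, with wide uncertainty. For compound 4 the estimated value is 1500 nM, with an expected range of 150 nM to 15000 nM.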

Compound 4, half-maximal inhibitory concentration: > 100000 nM
Compound 4 was reported as a limit; the forecaster's own chance of this, stated with the estimate: 7%; at least 66-fold (1.82 log units) between middle value and limit.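

In this assay, the place on a saturated chain carbon bound to a sulfur proved sensitive, with an at least 86-fold higher number from compound 3 to compound 4 (1.93 log units; beyond the scatter) when (3-hydroxy-4-methoxyphenyl)carbonyl replaced 4-methoxyphenyl. The earlier step at this place gave no firm direction, whereas this one lies beyond the scatter, and keeping the dimethylamino group did not protect compound 4. Its true size stays open, since compound 4 stands at a limit: the limit of > 100000 nM in this assay, at which 1 of the 4 values shown sits.

The carbonyl and the hydroxy group entered together, so which of them matters remains unresolved. From the compounds shown here alone, a plain (4-methoxyphenyl)carbonyl group, an amine or a carboxylic acid at this place also remains open.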